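Compound 2 to compound 4: bromo in place of chloro

A few compounds are considered here, and "the series" means these few. Any claim that something is new, unique, unknown or untested is made for them only; others in the source may bear on it.

In a functional assay on KB cells (Homo sapiens) for inhibition (on this read-out higher numbers stand for weaker inhibition and lower numbers for stronger inhibition), compound 2 (`FC(F)(F)c1cc(Cn2c(Cl)nc3cc(Cl)c(Cl)cc32)cc(C(F)(F)F)c1`) reads > 100000 nM, which is a limit and not a number. Compound 1 (`FC(F)(F)c1cccc(Cn2c(Cl)nc3cc(Cl)c(Cl)cc32)c1`) reads > 100000 nM, also a limit. Among the compounds with values here, the one measured step, a step that the two limits leave unreadable from compound 1 to compound 2, therefore gives no size to carry forward. Compound 4 (`FC(F)(F)c1cc(Cn2c(Br)nc3cc(Cl)c(Cl)cc32)cc(C(F)(F)F)c1`) has bromo in place of chloro on an aromatic carbon. Within the data shown here, no measured step isolates this change. Compound 3 (`Clc1cc2nc(Br)n(Cc3ccccc3Cl)c2cc1Cl`) carries bromo at that place, differs elsewhere and gives 78000 nM, so the expectation rests on compound 3 at 78000 nM. The expected step, an at least 1.1-fold lower number from compound 2 to compound 4 (0.04 log units; that floor lies within the scatter), is not expected to exceed the scatter. Compound 4 is estimated at 90000 nM, with an expected range of 40000 nM to 200000 nM.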

Compound 4, half-maximal inhibitory concentration: 70000 nM
Compound 4: middle estimate off by 1.3-fold (0.11 log units), on the high side; the range from low to high includes it.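

Bromo in place of chloro, on the aromatic carbon between two ring nitrogen atoms, gives an at least 1.4-fold lower number from compound 2 to compound 4 (0.15 log units; that floor lies within the scatter) in this assay. Within the data shown here, this is the first change at this place that yields a floor for a step, though that floor does not establish a change beyond the scatter. The step can only be stated as a floor because the value of compound 2 is a limit and not a number: the limit of > 100000 nM in this assay, at which 2 of the 4 values shown sit.

As far as these compounds go, the true size of the step remains open. From the compounds shown here alone, how an amine or a nitrile at this place would read in this assay also remains open.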